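A few compounds are considered here, and "the series" means these few. Any claim that something is new, unique, unknown or untested is made for them only; others in the source may bear on it.

In a functional assay on MCF7 cells (Homo sapiens) for antiproliferative activity, read by MTT assay, with a stated time of 72 h (a lower number here means a stronger inhibitor, a higher number a weaker inhibitor), compound 1 (`CCNC(=O)c1cc(Oc2ccc(NC(=O)c3nn(-c4ccc(Br)cc4F)c(=O)cc3C)cc2)ccn1`) gives 35100 nM. Compound 2 (`CCNC(=O)c1cc(Oc2ccc(NC(=O)c3nn(-c4ccc(C)cc4)c(=O)cc3C)cc2)ccn1`) gives 51300 nM, so the two values lie within the scatter of each other. Compound 3 (`CCNC(=O)c1cc(Oc2ccc(NC(=O)c3nn(-c4cccc(C(F)(F)F)c4)c(=O)cc3C)cc2)ccn1`) has 3-(trifluoromethyl)phenyl in place of 4-methylphenyl on an aromatic nitrogen. Within the data shown here, the only measured step bearing on this change, a 1.5-fold higher number from compound 1 to compound 2 (0.16 log units; within the scatter), also exchanged the group on that aromatic nitrogen. No change beyond the scatter, in either direction, is therefore expected in this assay. The expected step is a 1.3-fold lower number from compound 2 to compound 3 (0.11 log units; within the scatter). The estimated value for compound 3 is 40000 nM, with an expected range of 15000 nM to 100000 nM.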

Compound 3, half-maximal inhibitory concentration: 40600 nM
For compound 3 the middle estimate is 1.0-fold (0.01 log units) below the measured one; low and high end bracket the measured number.
By their numbers in this assay, from the lowest: compounds 1, 3 and 2 (each within the scatter of the next).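

In this assay, 3-(trifluoromethyl)phenyl on the aromatic nitrogen stays within the scatter of 4-methylphenyl (a 1.3-fold lower number from compound 2 to compound 3 (0.10 log units; within the scatter)) and of 4-bromo-2-fluorophenyl (a 1.2-fold higher number from compound 1 to compound 3 (0.06 log units; within the scatter)). This position has now taken three differently substituted phenyl groups without a separable change in the number. Nothing available accounts for this flat result.

As far as these compounds go, whether a carboxylic acid or an amine on that phenyl ring, or a plain alkyl chain in its place, would give a step beyond the scatter remains open. So does whether any change outside this position moves the number.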